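Adding a basic side-chain group to a macrocyclic boronate

The source may hold more compounds than are shown below. What is called first, only, known or untested is meant among the compounds shown, and "the series" means these compounds.

Measured compounds:
compound 1, `CCCCCCc1ccc(-c2ccc(C(=O)N[C@@H](CCCN)C(=O)N[C@H](C(=O)N[C@@H](C)C(=O)N[C@H]3Cc4cn(nn4)CCCN4C[C@@H]5OB(O[C@@H]5C4)[C@H](C)NC3=O)[C@@H](C)O)cc2)cc1`, in an ADME assay on HepG2 cells (Homo sapiens) for cytotoxicity, with a stated time of 72 h (a higher number here means a weaker inhibitor, a lower number a stronger inhibitor), compound 1 gives 4000 nM.
compound 2, `C[C@@H]1NC(=O)[C@@H](NC(=O)[C@H](C)NC(=O)[C@@H](NC(=O)[C@H](CCCN)NC(=O)c2ccc(-c3ccccc3)cc2)[C@@H](C)O)Cc2cn(nn2)CCO[C@@H]2C[C@@H]3OB1O[C@@H]3C2`, in this assay compound 2 gives > 64000 nM, which is a limit of the assay and not a number.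

Going by the values given here, compound 1 is the only compound with an actual number here; the other value is a limit. Among the compounds with values here, compound 2 sits at the limit of > 64000 nM in this assay, at which 1 of the 2 values shown sits, so no step between the two measured compounds can be drawn.

Compound 3, `CCCCCCc1ccc(-c2ccc(C(=O)N[C@@H](CCCNC(=N)N)C(=O)N[C@H](C(=O)N[C@@H](C)C(=O)N[C@H]3Cc4cn(nn4)CCCN4C[C@@H]5OB(O[C@@H]5C4)[C@H](C)NC3=O)[C@@H](C)O)cc2)cc1`, has not yet been measured. It differs from compound 1 in one place: a group of 3 heavy atoms (1 carbon, 2 nitrogen; no ring) in place of a hydrogen atom, on an amine nitrogen. Within the data shown here, with no measured step available, the expectation for this change rests only on the number for compound 1. The step from compound 1 to compound 3 is expected to be small, a 1.3-fold higher number from compound 1 to compound 3 (0.10 log units; within the scatter), with no direction beyond the scatter. Compound 3 is therefore estimated at 5000 nM, within a range from 1500 nM to 20000 nM.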

Compound 3, half-maximal inhibitory concentration: 2400 nM
Compound 3: middle estimate off by 2.1-fold (0.32 log units), on the high side; the range from low to high includes it.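

Putting a group of 3 heavy atoms (1 carbon, 2 nitrogen) in place of a hydrogen atom on the amine nitrogen gives a 1.7-fold lower number from compound 1 to compound 3 (0.22 log units; within the scatter) in this assay. Going by these compounds alone, this is the first measured change at this nitrogen, and it shows that the nitrogen can carry this larger group while the number in this assay stays within the scatter of compound 1. Nothing measured here gives a reason for the size of this step.

As far as these compounds go, whether a different group on this nitrogen, such as an acetyl group or a longer alkyl chain, would also stay within the scatter remains open. Within the data shown here, compound 2 gives only a limit of the assay, > 64000 nM, and not a number, so no step involving it can be read.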